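A Double Stereo Inversion from Compound 3 to Compound 4

This account rests on a few compounds, and the source may have more. Where it says the series, first, only, none or still open, it means among the compounds named here.

In a functional assay on MCF7 cells (Homo sapiens) for antiproliferative activity, read by CellTiter-Glo, with a stated time of 5 days (on this read-out higher numbers stand for weaker inhibition and lower numbers for stronger inhibition), compound 1 `CC1=C(c2cccc(O)c2)C(c2ccc(OC[C@@H](C)N3CCCC3)cc2)Oc2ccc(O)cc21` gives 0.2 nM, compound 2 `CC1=C(c2cccc(O)c2)C(c2ccc(OC[C@H](C)N3CCCCC3)cc2)Oc2ccc(O)cc21` gives 0.1 nM and compound 3 `CC1=C(c2cccc(O)c2)C(c2ccc(OC[C@H](C)N3CC[C@@H](C)C3)cc2)Oc2ccc(O)cc21` gives 0.2 nM. Compound 3 therefore stands level with compound 1 at the digits shown, and all three values lie within the scatter of one another. Compound 4 `CC1=C(c2cccc(O)c2)C(c2ccc(OC[C@@H](C)N3CC[C@H](C)C3)cc2)Oc2ccc(O)cc21` is the next compound to be tested, and its structure relates to compound 3 as follows: the two compounds have the same atoms and bonds; at least one stereo element is drawn with a configuration in one of them and without one in the other: 2 of 3 stereo elements differ; a stereocentre at a saturated chain carbon is drawn S in compound 3 and R in compound 4; a stereocentre at a saturated ring carbon is drawn R in compound 3 and S in compound 4. Among the compounds with values here, three measured steps bear on this change only indirectly: a 2.0-fold lower number from compound 1 to compound 2 (0.30 log units; within the scatter), no change at the digits printed from compound 1 to compound 3 (within the scatter) and a 2.0-fold higher number from compound 2 to compound 3 (0.30 log units; within the scatter). None of them isolates a change of configuration, so the data give no direct measure of this double inversion. Within the data shown here, with compound 3 at 0.2 nM as the starting point and those small steps as the only guide, no shift beyond the scatter is expected in this assay, although a somewhat higher number remains possible. The expected step is a 1.5-fold higher number from compound 3 to compound 4 (0.18 log units; within the scatter). Compound 4 is estimated at 0.3 nM, with an expected range of 0.1 nM to 1.5 nM.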

Compound 4, half-maximal inhibitory concentration: 0.2 nM
Beside the measured number, compound 4's estimate is 1.5-fold (0.18 log units) above it; measured number inside the range.
By their numbers in this assay, from the lowest: compounds 2, 1, 3 and 4 (each within the scatter of the next).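

In this assay, within the data shown here, the double inversion gives no change at the digits printed from compound 3 to compound 4 (within the scatter), the first step here that changes configuration alone, at the saturated chain carbon and the saturated ring carbon together. The methyl in place of hydrogen on a saturated ring carbon can now be read on its own, with no change at the digits printed from compound 1 to compound 4 (within the scatter), and the exchange of the six-membered ring group for the five-membered one gives a 2.0-fold higher number from compound 2 to compound 4 (0.30 log units; within the scatter). Neither the paired inversion nor the methyl moves the number beyond the scatter, with one caveat on the stereo comparison: the fact that one of compounds 3 and 4 is drawn with a defined configuration and the other without, at the place where they differ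

On these data alone, what inverting either centre alone does remains open. So does whether a dimethylamine in place of the ring amine, or an ethyl in place of the ring methyl, would hold these numbers.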